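A few compounds are considered here, and "the series" means these few. Any claim that something is new, unique, unknown or untested is made for them only; others in the source may bear on it.

Compound 1 `COc1ccc(-c2cnc(NC(=O)c3ccc(F)cc3)n2Cc2ccccc2)cc1` — > 100000 nM
Compound 2 `COc1ccc(-c2cnc(NC(=O)C3CCNCC3)n2C)cc1` — > 100000 nM

In a toxicity assay on THP-1 cells (Homo sapiens) for inhibition (a higher number here means that more compound is tolerated, a lower number that less compound is tolerated), compound 1 gives > 100000 nM, which is a limit of the assay rather than a number. Compound 2 reaches > 100000 nM in this assay, again a limit and not a number. Both results therefore sit at the limit of > 100000 nM in this assay, at which 2 of the 2 values shown sit. Among the compounds with values here, compound 2 thus stands at that limit without an exact figure, and since the only other value shown is a limit as well, no order between the two compounds can be drawn.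

Compound 3 `COc1ccc(-c2cnc(NC(=O)C3CCCC3)n2C)cc1` differs from compound 2 in one place: cyclopentyl in place of piperidin-4-yl on a carbonyl carbon. Within the data shown here, no step between measured compounds has been recorded, so there is no measured change to set the expected size against. Given that compound 2 sits at the limit of > 100000 nM in this assay, at which 2 of the 2 values shown sit, the expected step of a number no higher from compound 2 to compound 3 (the limit leaves the size open) amounts to none beyond the scatter, and a further limit rather than a number is the most likely outcome. The estimate for compound 3 in this assay is 100000 nM, with a range from 40000 nM to 250000 nM.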

Compound 3, half-maximal cytotoxic concentration: > 100000 nM
Compound 3: a limit, no number; the forecaster's own chance of this, stated with the estimate: 80%; the middle value sits exactly at the limit.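

In this assay compound 3 gives > 100000 nM, a limit of the assay and not a number. Within the data shown here, compound 2 also stands at a limit, so no step from compound 2 to compound 3 can be read: the limit of > 100000 nM in this assay, at which 3 of the 3 values shown sit. The compounds shown leave open whether cyclopentyl in place of piperidin-4-yl changes the tolerated concentration at all.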